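The source may hold more compounds than are shown below. What is called first, only, known or untested is meant among the compounds shown, and "the series" means these compounds.

Compound 1 `CCc1ccc2[nH]c(-c3ccccc3)c(C3=C(Br)C(=O)NC3=O)c2c1` and compound 2 `CCCc1ccc2[nH]c(-c3ccccc3)c(C3=C(Br)C(=O)NC3=O)c2c1` share one core, while compound 3 `COc1cccc(-c2[nH]c3ccc(C)cc3c2C2=C(Br)C(=O)NC2=O)c1` carries another; the difference between the two cores is not broken down here. In a physicochemical assay for lipophilicity (on this read-out higher numbers stand for higher lipophilicity and lower numbers for lower lipophilicity), compound 1 gives 3.15 and compound 2 gives 3.43. In this assay compound 3 gives 3.12, the lowest of the three numbers, within the scatter of compound 1 and beyond it only against compound 2. The step of a number 0.28 log units higher from compound 1 to compound 2 (within the scatter) comes from methyl in place of hydrogen on a saturated chain carbon, two bonds along the chain from an aromatic carbon. Compound 4 `CCc1ccc2[nH]c(-c3cccc(OC)c3)c(C3=C(Br)C(=O)NC3=O)c2c1` is not yet measured; it differs from compound 3 by methyl in place of hydrogen on a saturated chain carbon bound to an aromatic carbon. The two changes are of the same kind rather than the same, since in compound 2 the methyl enters two bonds along the chain from an aromatic carbon, whereas in compound 4 it enters on a saturated chain carbon bound to an aromatic carbon. The expected step of a number 0.28 log units higher from compound 3 to compound 4 (within the scatter) rests on that earlier change, because a number 0.28 log units higher from compound 1 to compound 2 (within the scatter) is the only measured case of this kind. Compound 4 is thus estimated at 3.4 in this assay, expected to fall between 3.1 and 3.7.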

Compound 4, partition coefficient: 3.35
Compound 4: middle estimate off by 0.05 log units, on the high side, and the stated range covers the measured number.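

In this assay the methyl change gives a number 0.23 log units higher from compound 3 to compound 4 (within the scatter), and the earlier case gave a number 0.28 log units higher from compound 1 to compound 2 (within the scatter), so the printed numbers point the same way on both cores. This does not show that the change carries over as a fixed amount: each step lies within the scatter, each core supplies a single pair, and the methyl enters at a different place in each, so the two are of one kind rather than one identical change; likewise, methoxy in place of hydrogen on an aromatic carbon gives a number 0.20 log units higher from compound 1 to compound 4 (within the scatter), which also stays within the scatter. No measurement offered here accounts for these numbers.

The compounds shown leave open whether a longer chain, such as butyl, would produce a step beyond the scatter on either core. They also leave open how an amine or a carboxylic acid would read at that place on a saturated chain carbon bound to an aromatic carbon.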